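From 4-fluorophenyl to 3-fluorophenyl on the shared core

A few compounds are considered here, and "the series" means these few. Any claim that something is new, unique, unknown or untested is made for them only; others in the source may bear on it.

Values in a functional assay on MCF7 cells (Homo sapiens) for cytotoxicity, read by MTT assay, with a stated time of 48 h; a lower number here means a stronger inhibitor, a higher number a weaker inhibitor:
- compound 1 `Fc1cccc(-c2nc(Nc3ccccc3)c3cc(F)ccc3n2)c1`: 49700 nM
- compound 2 `COc1ccccc1Nc1nc(-c2cccc(F)c2)nc2ccc(F)cc12`: > 50000 nM (a limit)
- compound 3 `Fc1ccc(Nc2nc(-c3cccc(F)c3)nc3ccc(F)cc23)cc1`: > 50000 nM (a limit)

Compound 3 has no number, only a limit of > 50000 nM. That is the limit of > 50000 nM in this assay, at which 2 of the 3 values shown sit.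

Compound 4 `Fc1cccc(Nc2nc(-c3cccc(F)c3)nc3ccc(F)cc23)c1` carries 3-fluorophenyl in place of 4-fluorophenyl on a nitrogen on an aromatic ring.

Going by the values given here, three measured steps bear on this change: a number no lower from compound 1 to compound 3 (the limit leaves the size open), a number no lower from compound 1 to compound 2 (the limit leaves the size open) and a step that the two limits leave unreadable from compound 2 to compound 3. None of them gives a size, so the series offers no measured effect of moving the fluoro group. Among the compounds with values here, the only number is that compound 1 gives 49700 nM in this assay. On that basis, no step beyond the scatter is expected. The expected step is a number no higher from compound 3 to compound 4 (the limit leaves the size open). A limit is again a likely report for this compound. For compound 4 the estimated value is 50000 nM. The expected range for compound 4 runs from 25000 nM to 100000 nM.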

Compound 4, half-maximal inhibitory concentration: 48700 nM
Compound 4: middle estimate off by 1.0-fold (0.01 log units), on the high side; low and high end bracket the measured number.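

In this assay, going by these compounds alone, the 3-fluorophenyl on the nitrogen gives the first step with a readable size for fluoro in place of hydrogen on this phenyl: a 1.0-fold lower number from compound 1 to compound 4 (0.01 log units; within the scatter). Against the groups that gave only limits, the result reads as an at least 1.0-fold lower number from compound 3 to compound 4 (0.01 log units; that floor lies within the scatter) and as an at least 1.0-fold lower number from compound 2 to compound 4 (0.01 log units; that floor lies within the scatter), so neither step shows a gain beyond the scatter. The values of compound 2 and compound 3 remain limits, and their distance from compound 4 therefore has no upper bound: the limit of > 50000 nM in this assay, at which 2 of the 4 values shown sit.

As far as these compounds go, the true size of the change from 4-fluorophenyl to 3-fluorophenyl stays open. Also open, from the compounds shown here alone, is whether a group of another kind on this phenyl, such as a dimethylamino group or a carboxylic acid, would move the number beyond the scatter.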